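A few compounds are considered here, and "the series" means these few. Any claim that something is new, unique, unknown or untested is made for them only; others in the source may bear on it.

Working notes on the series. In a functional assay on PC-3 cells (Homo sapiens) for inhibition, with a stated time of 72 h (a lower number here means a stronger inhibitor, a higher number a weaker inhibitor), compound 1 `O=C(Nc1ccccc1)Nc1nc(Sc2c[nH]c3ccccc23)cc(N2CCN(Cc3ccccc3)CC2)n1` gives 42500 nM, compound 2 `O=C(Nc1ccccc1)Nc1nc(Nc2ccccc2)cc(Sc2c[nH]c3ccccc23)n1` gives 26400 nM, and compound 3 `O=C(Nc1ccccc1)Nc1nc(Sc2c[nH]c3ccccc23)cc(N2CCCCC2)n1` gives 12100 nM. Among the measured compounds shown here, the one single-site step among them is a 2.2-fold lower number from compound 2 to compound 3 (0.34 log units; beyond the scatter). On these three numbers compound 3 holds the lowest value: compound 2 is the nearest to it and compound 1 the furthest, both beyond the scatter.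

Compound 4 `O=C(Nc1ccccc1)Nc1nc(Sc2c[nH]c3ccccc23)cc(N2CCN(c3ccccn3)CC2)n1` is not yet measured in this assay. It differs from compound 3 in one place: 4-(pyridin-2-yl)piperazin-1-yl in place of piperidin-1-yl on an aromatic carbon. For the measured compounds named here, no measured step bears directly on this change. Going by the values given here, the only related comparison is between compound 1 and compound 3, where the larger benzyl-piperazine substituent of compound 1 sits well above compound 3; a 4-(pyridin-2-yl)piperazin-1-yl group is closer to that larger substituent than to piperidin-1-yl. On that basis the number for compound 4 is expected to rise, a step of about a 2.1-fold higher number from compound 3 to compound 4 (0.32 log units; beyond the scatter), with wide uncertainty. Compound 4 is therefore estimated at 25000 nM, in the range 8000 nM to 70000 nM.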

Compound 4, half-maximal inhibitory concentration: 21600 nM
Estimate against measurement, compound 4: 1.2-fold (0.06 log units) above, within the range that was stated.
By their numbers in this assay, from the lowest: compounds 3, 4, 2 and 1 (each within the scatter of the next, the first and the last beyond it).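

In this assay, a step of a 1.8-fold higher number from compound 3 to compound 4 (0.25 log units; within the scatter) means that, on the aromatic carbon next to the ring nitrogen, 4-(pyridin-2-yl)piperazin-1-yl cannot be told apart from piperidin-1-yl, although it is the larger group by heavy atoms. The other two comparisons read the same way: a 1.2-fold lower number from compound 2 to compound 4 (0.09 log units; within the scatter) leaves 4-(pyridin-2-yl)piperazin-1-yl and anilino unseparated, and a 2.0-fold lower number from compound 1 to compound 4 (0.29 log units; within the scatter) does the same for pyridin-2-yl and benzyl on the amine nitrogen in a ring. No measurement is available that would explain these results.

The compounds shown leave open whether morpholin-4-yl or a small open-chain amine such as dimethylamino at this position would give a clearly different number. Also open, as far as these compounds go, is how a piperazine carrying a carboxylic acid in place of pyridin-2-yl would read.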